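This account rests on a few compounds, and the source may have more. Where it says the series, first, only, none or still open, it means among the compounds named here.

Measured compounds:
Compound 1, `c1ccc(-c2ccc3c(NCCCNCc4ccco4)ccnc3c2)cc1`: 9.47
Compound 2, `COc1ccc(F)cc1CNCCCNc1ccnc2cc(Cc3ccc(F)cc3)ccc12`: 9.47
Compound 3, `COc1ccc(-c2ccc3c(NCCCNCc4ccco4)ccnc3c2)cc1`: 9.47

These three compounds were each measured in a physicochemical assay for acid dissociation, and all three come out at the same number. Compound 3 therefore stands level with compound 1 and with compound 2, its nearest and furthest neighbours alike, with no difference beyond the scatter. Among the compounds with values here, the one single-point step among them, no change at the digits printed from compound 1 to compound 3 (within the scatter), shows that adding a methoxy to an aromatic carbon of the shared core left the value unchanged.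

Compound 4, `COc1ccc(-c2ccc3c(NCCCNCc4cc(F)ccc4OC)ccnc3c2)cc1`, has not yet been measured. It differs from compound 3 in one place: 5-fluoro-2-methoxyphenyl in place of furan-2-yl on a saturated chain carbon bound to an amine nitrogen. Within the data shown here, no measured step isolates this exact swap. What the data do offer is that compound 1, carrying the (furan-2-yl)methyl group, and compound 2, carrying the 5-fluoro-2-methoxybenzyl group on the same kind of amine, give the same value in this assay, although those two compounds also differ elsewhere. With every measured value in this set sitting at one number, the expectation is that compound 4 will show no step beyond the scatter, no change at the digits printed from compound 3 to compound 4 (within the scatter). Compound 4 is accordingly estimated at 9.47, within a range from 9.1 to 9.8.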

Compound 4, acid dissociation constant: 9.47
Compound 4: middle estimate and measured number agree at the digits printed, within the range that was stated.
By their numbers in this assay, from the lowest: compounds 1, 2, 3 and 4 (each within the scatter of the next).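

In this assay, the exchange of furan-2-yl for 5-fluoro-2-methoxyphenyl on a saturated chain carbon bound to an amine nitrogen can now be read directly as a single change, and the result is no change at the digits printed from compound 3 to compound 4 (within the scatter). This shows that a five-membered aromatic ring with a hetero atom and a larger six-membered aromatic ring of carbon only give the same reading at this position on this core, and a second single change, 4-methoxyphenyl in place of 4-fluorobenzyl on an aromatic carbon, reads no change at the digits printed from compound 2 to compound 4 (within the scatter). No measurement available here accounts for why the number stays level across these changes.

Every group shown on this chain carbon is an aromatic ring, so what a carboxylic acid, a primary amine or a longer alkyl chain would do at this position remains open. With all four compounds sitting at the same value, the set also leaves open which part of the structure, if any, this read-out responds to, and only a compound that departs from that value could begin to answer this.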